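A few compounds are considered here, and "the series" means these few. Any claim that something is new, unique, unknown or untested is made for them only; others in the source may bear on it.

Measured compounds, all in an ADME assay on KB cells (Homo sapiens) for cytotoxicity, read by resazurin assay, with a stated time of 72 h; a lower number here means a stronger inhibitor, a higher number a weaker inhibitor:
- compound 1, `Cc1c(OCc2ccccc2)c(=O)ccn1CCNc1ccnc2cc(Cl)ccc12`, gives 54000 nM
- compound 2, `Cc1c(OCc2ccccc2)c(=O)ccn1CCCCNc1ccnc2cc(Cl)ccc12`, gives 119000 nM
- compound 3, `CCc1c(OCc2ccccc2)c(=O)ccn1CCNc1ccnc2cc(Cl)ccc12`, gives 51000 nM

Compound 3 is compound 1 with methyl in place of hydrogen on a saturated chain carbon bound to an aromatic carbon, and this change gave a 1.1-fold lower number from compound 1 to compound 3 (0.02 log units; within the scatter). Compound 2 shares much with compound 1 but has a different core; the difference between the two cores is not broken down here. Compound 4, `CCc1c(OCc2ccccc2)c(=O)ccn1CCCCNc1ccnc2cc(Cl)ccc12`, is compound 2 carrying the same change, (methyl in place of hydrogen on a saturated chain carbon bound to an aromatic carbon), at the same place. Because the step of a 1.1-fold lower number from compound 1 to compound 3 (0.02 log units; within the scatter) stayed within the scatter, a step of similar size is expected here, a 1.1-fold lower number from compound 2 to compound 4 (0.03 log units; within the scatter), which would leave compound 4 close to compound 2. Compound 4 is therefore estimated at 110000 nM in this assay. Compound 4 is expected to fall between 55000 nM and 220000 nM.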

Compound 4, half-maximal inhibitory concentration: 9000 nM
Estimate against measurement, compound 4: 12-fold (1.09 log units) above, and the stated range ends above it.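

In this assay, putting methyl in place of hydrogen on a saturated chain carbon bound to an aromatic carbon gave a 13-fold lower number from compound 2 to compound 4 (1.12 log units; beyond the scatter) and so counts as a large step. The same change therefore did not have an effect of the same size on the two cores: the same change on two cores in this assay, a 1.1-fold lower number (0.02 log units; within the scatter) from compound 1 to compound 3 and a 13-fold lower number (1.12 log units; beyond the scatter) from compound 2 to compound 4, 12-fold (1.10 log units) apart, beyond the scatter of two such steps
This shows that, for these two pairs, the size of the step cannot simply be carried from one core to the other, but it does not show which feature of the cores is responsible. Two pairs also give no rule for the rest of the series.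

Still open, from the compounds shown here alone, is what a longer chain, such as propyl, or a hydroxyl group would do at the same place on each core. Also open, going by these compounds, is whether other cores would follow the small step or the large one.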